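A single ring stereocentre inverted in compound 2

The compounds below may be only part of what the source reports. "The series", "measured", "known", "first", "only" and "open" are said of these compounds alone.

Measured so far:
compound 1 `O=C(O)C[C@H]1CCC(=O)[C@@H]1C/C=C\CCO[C@@H]1O[C@H](COC(=O)c2cc(O)c(O)c(O)c2)[C@@H](O)[C@H](O)[C@H]1O`: 11200 nM
compound 2 `CC1=CC[C@@H](C(C)(C)O[C@@H]2O[C@H](CO[C@@H]3O[C@@H](CO)[C@H](O)[C@H]3OC(=O)c3cc(O)c(O)c(O)c3)[C@@H](O)[C@H](O)[C@H]2O)CC1`: 10500 nM

In a functional assay, with a stated time of 180 min (on this read-out lower numbers stand for stronger inhibition and higher numbers for weaker inhibition), compound 2 and compound 1 give numbers that sit within the scatter of each other, so neither stands apart. Compound 3 `CC1=CC[C@H](C(C)(C)O[C@@H]2O[C@H](CO[C@@H]3O[C@@H](CO)[C@H](O)[C@H]3OC(=O)c3cc(O)c(O)c(O)c3)[C@@H](O)[C@H](O)[C@H]2O)CC1` differs from compound 2 in one respect: the two compounds have the same atoms and bonds and differ only in configuration as drawn: 1 of 10 stereo elements differ; a stereocentre at a saturated ring carbon is drawn S in compound 2 and R in compound 3. Among the measured compounds shown here, no pair of measured compounds shows what such a change in configuration does here, so there is no measured step to lean on. The expectation for compound 3 in this assay is therefore no shift beyond the scatter in either direction. Compound 3 is expected to give 11000 nM, with a range of 5000 nM to 25000 nM. The step of a 1.0-fold higher number from compound 2 to compound 3 (0.02 log units; within the scatter) is accordingly estimated to stay within the scatter.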

Compound 3, half-maximal inhibitory concentration: 11600 nM
For compound 3 the middle estimate is 1.1-fold (0.02 log units) below the measured one, and the stated range covers the measured number.
By their numbers in this assay, from the lowest: compounds 2, 1 and 3 (each within the scatter of the next).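

Inverting the stereocentre at the saturated ring carbon from S to R in this assay gives a 1.1-fold higher number from compound 2 to compound 3 (0.04 log units; within the scatter) and so supplies the first measured step for a change in configuration in this series. At this position, the read-out does not separate the two drawn forms. The comparison isolates this single stereocentre: the fact that compounds 2 and 3 differ only in the configuration as drawn

The compounds shown leave open whether the other stereo elements would behave in the same way. They also leave open whether an amine or a longer chain on that saturated ring would move the number beyond the scatter.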